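Ester side chain variation on a shared dihydropyridine-free core

The source may report more compounds than this note shows. Statements on the series, on what has been measured and on what is new or still open speak of the compounds shown alone.

Compound 1 `COC(=O)C1=C(C)NC(C)=C(C(=O)OC2C=CCCC2)C1c1cccc([N+](=O)[O-])c1` and compound 2 `COC(=O)C1=C(C)NC(C)=C(C(=O)OCCC(C)c2ccccc2)C1c1cccc([N+](=O)[O-])c1` share one core and differ only in the alcohol part of one ester. In a functional assay on HEK293 cells for antagonist activity at Voltage-dependent L-type calcium channel subunit alpha-1D (Rattus norvegicus), read by FLIPR (on this read-out higher numbers stand for weaker inhibition and lower numbers for stronger inhibition), compound 1 gives 10 nM and compound 2 gives 11 nM; the step of a 1.1-fold higher number from compound 1 to compound 2 (0.04 log units; within the scatter) shows that exchanging one ester group for another leaves the number where it was. Compound 2 is one of only two numbers shown; its nearest and only neighbour is compound 1, and the gap between them lies within the scatter.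

Compound 3 `COC(=O)C1=C(C)NC(C)=C(C(=O)OCCCCc2ccc(OC)cc2)C1c1cccc([N+](=O)[O-])c1` is not yet measured. It differs from compound 2 by 2-(4-methoxyphenyl)ethyl in place of 1-phenylethyl on a saturated chain carbon, two bonds along the chain from an oxygen next to a carbonyl group. Going by the values given here, the one measured step that bears on this position, a 1.1-fold higher number from compound 1 to compound 2 (0.04 log units; within the scatter), concerns the same ester oxygen but a different group, so it gives only a loose guide. Nothing measured here speaks to the methoxy group. The expectation for compound 3 in this assay is therefore no step beyond the scatter, and a 1.1-fold higher number from compound 2 to compound 3 (0.04 log units; within the scatter) is the expected change. Compound 3 is estimated at 12 nM, with a range from 5 nM to 30 nM.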

Compound 3, half-maximal inhibitory concentration: 38 nM
The estimate for compound 3 lay 3.2-fold (0.50 log units) below the measured number, outside the stated range (above it).
By their numbers in this assay, from the lowest: compounds 1 and 2 (each within the scatter of the next); then compound 3.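

The ester side chain is not indifferent in this assay: the exchange between compound 1 and compound 2 stayed within the scatter, whereas 2-(4-methoxyphenyl)ethyl in place of 1-phenylethyl gives a 3.5-fold higher number from compound 2 to compound 3 (0.54 log units; beyond the scatter). Measured against the cyclohex-2-en-1-yl ester, 4-(4-methoxyphenyl)butyl gives a 3.8-fold higher number from compound 1 to compound 3 (0.58 log units; beyond the scatter), so this side chain separates from both earlier esters by a modest step in the direction of weaker inhibition, and the tolerance suggested by the first pair does not extend to every group at this oxygen. No measurement at hand accounts for this step.

The step from 3-phenylbutyl to 4-(4-methoxyphenyl)butyl changes the chain and brings in the methoxy group together, and the compounds shown do not divide the step between these two changes, which an unsubstituted 4-phenylbutyl ester would begin to do. Going by these compounds, how a longer chain, a terminal amine or a hydroxyl group in place of the methoxy group would read in this assay also stays open.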